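The source may report more compounds than this note shows. Statements on the series, on what has been measured and on what is new or still open speak of the compounds shown alone.

Working notes on the series. In a functional assay on T-24 cells (Homo sapiens) for cytotoxicity, read by CCK-8 assay, with a stated time of 24 h (on this read-out lower numbers stand for stronger inhibition and higher numbers for weaker inhibition), compound 1 `C=C1CCC(c2csc(/C=C(\C)C(N)=O)c2)CC1` gives > 50000 nM, which is a limit of the assay and not a number. Compound 2 `C/C(=C\c1cc(-c2cccnc2)co1)C(N)=O` likewise gives only a limit, > 50000 nM. Compound 3 `C/C(=C\c1cc(-c2ccc(C)nc2)co1)C(N)=O` also gives only a limit, > 50000 nM. Compound 3 thus stands at the same limit as the other two measured compounds, and nothing separates them on the numbers shown. Among the measured compounds shown here, the single step among measured compounds, a step that the two limits leave unreadable from compound 2 to compound 3, is unreadable because the limit of > 50000 nM in this assay, at which 3 of the 3 values shown sit, holds both of its ends.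

Compound 4 `C/C(=C\c1cc(-c2ccc(F)nc2)co1)C(N)=O` differs from compound 3 in one place: fluoro in place of methyl on an aromatic carbon. For the measured compounds named here, the one measured step on this ring, a step that the two limits leave unreadable from compound 2 to compound 3, bears on the same position but gives no size, so no measured step tells how large a step this change should bring. Going by the values given here, with every compound so far at the limit and no readable movement, no step beyond the scatter is expected, and the expected step is a number no higher from compound 3 to compound 4 (the limit leaves the size open). Compound 4 is therefore estimated at 50000 nM, with a range from 20000 nM to 150000 nM, and is most likely to come back as a limit again rather than a number.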

Compound 4, half-maximal inhibitory concentration: > 50000 nM
Compound 4 ended at the assay's limit; the forecaster's own chance of this, stated with the estimate: 80%; the middle value lies on the limit itself.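

In this assay compound 4 gives > 50000 nM, a limit of the assay and not a number. The steps to compound 4 from compound 2 and compound 3 cannot be read, because each has both ends at one limit: the limit of > 50000 nM in this assay, at which 4 of the 4 values shown sit.

The compounds shown leave open what size of step, if any, methyl or fluoro brings on this ring.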